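A Thiazole Swap Tested for Cell Tolerance

The compounds below may be only part of what the source reports. "The series", "measured", "known", "first", "only" and "open" are said of these compounds alone.

Three compounds share one core and differ in the groups attached to it. Compound 1 has the structure `CCCCNc1nc(N)nc2ccn(Cc3ccccc3)c12`, compound 2 is `CCCCNc1nc(N)nc2ccn(Cc3ncc(C)c(OC)c3C)c12`, and compound 3 is `COCCNc1nc(N)nc2ccn(Cc3ccccn3)c12`. All three have been tested in an ADME assay on HEK293 cells (Homo sapiens) for cytotoxicity, read by ATP content, with a stated time of 6 h; a higher number here means that more compound is tolerated, a lower number that less compound is tolerated. In this assay compound 1 gives > 24000 nM, which is a limit of the assay rather than a number. Compound 2 likewise gives > 24000 nM, again a limit. Compound 3 stands at > 24000 nM, also a limit. So compound 3 sits where every measured compound sits, namely at the limit of > 24000 nM in this assay, at which 3 of the 3 values shown sit, with no numbered value to set them apart.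

Compound 4, with the structure `Cc1cnc(CNc2nc(N)nc3ccn(Cc4ccccn4)c23)s1`, has not yet been measured in this assay. It differs from compound 3 in one place: 5-methyl-1,3-thiazol-2-yl in place of methoxymethyl on a saturated chain carbon bound to a nitrogen on an aromatic ring. Within the data shown here, no step between measured compounds is on record, so the expectation rests on the three limits alone. Because every measured compound sits at the limit of > 24000 nM in this assay, at which 3 of the 3 values shown sit, the step from compound 3 to compound 4 is expected to be a step that the limit leaves unreadable from compound 3 to compound 4, that is, nothing beyond the usual scatter. Compound 4 is therefore expected to give about 30000 nM in this assay, within a range from 15000 nM to 80000 nM, and most likely to be reported again only as a limit.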

Compound 4, half-maximal cytotoxic concentration: > 24000 nM
Compound 4 was reported as a limit (the forecaster's own chance of this, stated with the estimate: 75%); the middle value does not contradict the limit.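

Among these compounds, compound 3 and compound 4 both stand at a limit of the assay rather than at a number, and no step between them can be read. The compounds shown leave open at what concentration, if any, each one harms these cells, and all share one result: the limit of > 24000 nM in this assay, at which 4 of the 4 values shown sit.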